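The source may hold more compounds than are shown below. What is called first, only, known or untested is meant among the compounds shown, and "the series" means these compounds.

The account begins with two measured compounds. Compound 1 `CC1=NN(S(=O)(=O)c2ccc(C)cc2)C(c2cc(Br)cc(Br)c2O)C1` carries a pyrazoline bearing a dibrominated phenol, and in a functional assay on MGC-803 cells (Homo sapiens) for cytotoxicity, read by MTT assay, with a stated time of 48 h (on this read-out higher numbers stand for weaker inhibition and lower numbers for stronger inhibition), compound 1 is recorded as "not active" (no number reported), with no number attached to it. Going by the values given here, compound 2 `CCC(=O)N1N=C(c2cc3ccccc3oc2=O)CC1c1ccccc1` is the only compound of the pair with a numerical result: in this assay compound 2 gives 5300 nM, so it stands as the sole reference point on the scale, with compound 1 giving nothing that can be compared to it.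

Compound 3 `CCN(CC)C1CCN(CC(=O)N2N=C(c3cc4ccccc4oc3=O)CC2c2ccccc2)CC1` keeps the core of compound 2 and differs from it in one place: 4-(diethylamino)piperidin-1-yl in place of methyl on a saturated chain carbon bound to a carbonyl carbon. Among the compounds with values here, no measured pair in this set shows what such a change does, so the size of the step from compound 2 to compound 3 rests on the change alone. A moderate shift toward stronger inhibition in this assay is expected, though the estimate is wide enough that a result within the scatter of compound 2 is also possible. For compound 3 the expected step in this assay is a 2.7-fold lower number from compound 2 to compound 3 (0.42 log units; beyond the scatter), and compound 3 is estimated at 2000 nM, with a range from 500 nM to 15000 nM.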

Compound 3, half-maximal inhibitory concentration: 32400 nM
For compound 3 the middle estimate is 16-fold (1.21 log units) below the measured one; the whole stated range lies below it.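

Going by these compounds alone, at this place, a saturated chain carbon bound to a carbonyl carbon, putting 4-(diethylamino)piperidin-1-yl in place of methyl gives in this assay a 6.1-fold higher number from compound 2 to compound 3 (0.79 log units; beyond the scatter), the first measured step in the set, and it runs toward weaker inhibition. Within the data shown here, the position therefore still yields a number with the much larger group on it, but the shared core gains nothing in this assay from carrying that group, so the single step available here points against this exchange rather than for it. No data shown here bear on why the step runs in this direction.

On these data alone, one step cannot separate the piperidine ring from the diethylamino group on it, so it stays open whether a plain piperidine, a morpholine ring or a simple dimethylamino group at this place would read differently. As far as these compounds go, it also stays open how a longer alkyl chain such as butyl, or a carboxylic acid, in place of methyl would stand against compound 2 at 5300 nM in this assay.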